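Trading a Dienyl Chain for Octyl in a Weak Antiproliferative

This account rests on a few compounds, and the source may have more. Where it says the series, first, only, none or still open, it means among the compounds named here.

Measured so far:
compound 1, `CCCC/C=C\CCCCCCCCCc1cc(=O)c2c(O)cc(O)c(C)c2o1`, 17500 nM
compound 2, `CCCCC/C=C\C/C=C\CCCCCCCC1(O)CC(=O)c2c(O)cc(O)cc2O1`, 17500 nM
compound 3, `CCCCC/C=C\C/C=C\CCCCCCCc1cc(=O)c2c(O)cc(O)cc2o1`, 17500 nM

All three compounds were tested in a functional assay on MCF7 cells (Homo sapiens) for antiproliferative activity, read by MTT assay; a higher number here means a weaker inhibitor, a lower number a stronger inhibitor. In this assay compound 2 gives 17500 nM, and on the numbers shown compound 2 stands level with compounds 1 and 3 at the digits shown: its nearest neighbour is compound 1, with no change at the digits shown, and its furthest neighbour is compound 3, again with no change at the digits shown. Among the measured compounds shown here, every gap among the three lies within the scatter of repeated measurements, so no compound can be called stronger or weaker than another. For the measured compounds named here, no two of the measured compounds differ in only one place, so no single structural step has been measured.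

The next compound is compound 4, `CCCCCCCCCCCCCCCC1(O)CC(=O)c2c(O)cc(O)cc2O1`. It differs from compound 2 by one change: octyl in place of deca-1,4-dien-1-yl on a saturated chain carbon, seven bonds along the chain from a saturated ring carbon. Nothing measured here shows what such a change does. With the three measured compounds sitting together, the expectation is that compound 4 behaves like compound 2, giving a step from compound 2 to compound 4 of no change at the digits printed from compound 2 to compound 4 (within the scatter), that is none beyond the scatter. For compound 4 the estimate in this assay is 17500 nM, with a range from 8000 nM to 40000 nM.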

Compound 4, half-maximal inhibitory concentration: 17500 nM
Estimate against measurement, compound 4: no gap at the digits printed, within the range that was stated.
By their numbers in this assay, from the lowest: compounds 1, 2, 3 and 4 (each within the scatter of the next).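

In this assay, among the compounds shown here, the exchange of deca-1,4-dien-1-yl for octyl, on a saturated chain carbon, seven bonds along the chain from a saturated ring carbon, gives no change at the digits printed from compound 2 to compound 4 (within the scatter) and is the only single structural step that can be read in this set. It shows that this read-out does not separate the two chains at this position, even though octyl lacks the 2 double bonds outside aromatic rings, so those double bonds are not needed to keep the reading of compound 2. No supporting measurement is available to explain this result.

One step with one pair of chains cannot show whether any change at this place can move the reading beyond the scatter. From the compounds shown here alone, it remains open whether a longer chain, or an amine or a carboxylic acid on that saturated chain carbon, would give a result that differs from that of compound 2.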